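A few compounds are considered here, and "the series" means these few. Any claim that something is new, unique, unknown or untested is made for them only; others in the source may bear on it.

Working notes on a small series in a functional assay on HeLa cells (Homo sapiens) for inhibition, read by MTT assay, with a stated time of 48 h; a higher number here means a weaker inhibitor, a lower number a stronger inhibitor.

Compound 1 `O=C1CN(C2CCCC2)c2nc(Nc3ccc(N4CCCCC4)cn3)ncc2N1` carries a piperidin-1-yl group on its shared core. In this assay compound 1 reaches only a limit of the assay, > 30000 nM, and no number. Compound 2 `CC1CCN(c2ccc(Nc3ncc4c(n3)N(C3CCCC3)CC(=O)N4)nc2)CC1` differs from compound 1 by methyl in place of hydrogen on a saturated ring carbon. In this assay compound 2 likewise reaches only a limit, > 30000 nM. The resulting step that the two limits leave unreadable from compound 1 to compound 2 cannot be read, since (the limit of > 30000 nM in this assay, at which 2 of the 3 values shown sit).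

Compound 3 `CN1C(=O)CN(C2CCCC2)c2nc(Nc3ccc(N4CCCCC4)cc3)ncc21` has a different core; how the core of compound 3 differs from that of compound 1 is not broken down here. In this assay, among the measured compounds shown here, compound 3 gives 16900 nM, the only number among the three measured compounds.

Compound 4 `CC1CCN(c2ccc(Nc3ncc4c(n3)N(C3CCCC3)CC(=O)N4C)cc2)CC1` differs from compound 3 by methyl in place of hydrogen on a saturated ring carbon, the same change as from compound 1 to compound 2, at a place described in the same words. The earlier instance of this change gave no readable size. For compound 4 the step of a 1.1-fold lower number from compound 3 to compound 4 (0.02 log units; within the scatter) is expected to stay within the usual scatter, resting only on compound 3 at 16900 nM and on the small size of the entering methyl. Compound 4 is therefore estimated at 16000 nM, between 6000 nM and 40000 nM.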

Compound 4, half-maximal inhibitory concentration: > 30000 nM
Compound 4: only a limit was reported; the forecaster's own chance of this, stated with the estimate: 25%; middle value at least 1.8-fold (0.27 log units) away from the limit.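

In this assay compound 4 reaches only a limit (> 30000 nM) and no number. The step (an at least 1.7-fold higher number from compound 3 to compound 4 (0.24 log units; that floor lies within the scatter)) is therefore a floor: it shows that methyl in place of hydrogen on a saturated ring carbon, read as piperidin-1-yl to 4-methylpiperidin-1-yl, brought no lower number on the core of compound 3, but it does not fix the true size of the step or show that it goes beyond the scatter. It also does not show that the change behaves alike on the two cores, since the matching step on the core of compound 1 cannot be read, and the series offers little room for such a comparison: the limit of > 30000 nM in this assay, at which 3 of the 4 values shown sit.

Among the compounds shown here, compound 3 remains the only compound with a number, so nothing here shows what would lower that number. Still open, going by these compounds, is how an amine, a hydroxyl group, a carboxylic acid or a longer chain in place of the methyl of 4-methylpiperidin-1-yl would read on either core.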